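The source may report more compounds than this note shows. Statements on the series, on what has been measured and on what is new or still open speak of the compounds shown alone.

Measured in an ADME assay on L6 cells (Rattus norvegicus) for cytotoxicity, read by resazurin assay, with a stated time of 72 h; a higher number here means a weaker inhibitor, a lower number a stronger inhibitor:
compound 1 `O=C(CN1CCCCC1)OC1CC2(N3CCCC3)CC(c3ccccc3)C1C(c1ccccc1)C2` gives 14200 nM
compound 2 `NCC(=O)OC1CC2(N3CCCC3)CC(c3ccccc3)C1C(c1ccccc1)C2` gives 42900 nM
compound 3 `CN1CCN(CCC(=O)NC2CC3(N4CCCC4)CC(c4ccccc4)C2C(c2ccccc2)C3)CC1` gives 86700 nM

Compound 1 holds the lowest of the three numbers in this assay. The nearest step away from it is a 3.0-fold higher number from compound 1 to compound 2 (0.48 log units; beyond the scatter); the furthest is a 6.1-fold higher number from compound 1 to compound 3 (0.79 log units; beyond the scatter). Between the other two measured compounds, a 2.0-fold higher number from compound 2 to compound 3 (0.31 log units; beyond the scatter). All three measured steps alter the side chain on the saturated ring carbon that bears the ester or amide, or the amine at the end of that chain; none of them touches the ring carbon that bears the pyrrolidin-1-yl group.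

Compound 4 `CN(C)C12CC(OC(=O)CN3CCCCC3)C(C(c3ccccc3)C1)C(c1ccccc1)C2` differs from compound 1 at exactly that untested place: dimethylamino in place of pyrrolidin-1-yl on a saturated ring carbon. Among the measured compounds shown here, no measured step therefore bears directly on this change, and the series gives no direction for it. What the series does show is that even the side-chain changes moved the numbers only modestly, so a change of similar count at another position is expected to stay within or close to the scatter. The estimate for compound 4 in this assay is 16000 nM, with a range from 7000 nM to 36000 nM, which is an expected step of a 1.1-fold higher number from compound 1 to compound 4 (0.05 log units; within the scatter).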

Compound 4, half-maximal inhibitory concentration: 29300 nM
Estimate against measurement, compound 4: 1.8-fold (0.26 log units) below; the range from low to high includes it.
By their numbers in this assay, from the lowest: compound 1; then compounds 4 and 2 (each within the scatter of the next); then compound 3.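

In this assay the ring carbon bearing the pyrrolidin-1-yl group proves not to be a neutral place: dimethylamino in place of pyrrolidin-1-yl gives a 2.1-fold higher number from compound 1 to compound 4 (0.31 log units; beyond the scatter) and so moves the number beyond the scatter, though only modestly. Until now every step had altered the side chain or its terminal amine, and this step shows that the amine on the far ring carbon also registers, at a size of the same modest class as a 3.0-fold higher number from compound 1 to compound 2 (0.48 log units; beyond the scatter) on the side chain. The exchange removes the five-membered ring while the counted hydrogen-bond donors, acceptors and net charge stay the same, but no measurement shown explains why the number moves.

With a single pair at this position, no trend can be drawn from these two amines, and a piperidin-1-yl, a morpholin-4-yl or an unsubstituted amino group on the same ring carbon would show whether ring size or ring presence matters at all. Going by these compounds, it also remains open whether dimethylamino produces a similar step when paired with the aminomethyl ester of compound 2 or the 4-methylpiperazin-1-yl amide of compound 3.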